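A few compounds are considered here, and "the series" means these few. Any claim that something is new, unique, unknown or untested is made for them only; others in the source may bear on it.

Measured in a functional assay on HOS cells (Homo sapiens) for antiproliferative activity, with a stated time of 72 h (a lower number here means a stronger inhibitor, a higher number a weaker inhibitor), all values being limits:
- compound 1 `OC[C@H]1O[C@@H](n2cnc3c(NCc4ccccc4Br)ncnc32)[C@H](O)[C@@H]1O`: > 166000 nM
- compound 2 `OC[C@H]1O[C@@H](n2cnc3c(NCc4ccc(Br)cc4)ncnc32)[C@H](O)[C@@H]1O`: > 166000 nM
- compound 3 `OC[C@H]1O[C@@H](n2cnc3c(NCc4cccc(O)c4O)ncnc32)[C@H](O)[C@@H]1O`: > 166000 nM

Compound 3 has no numeric value, only the limit > 166000 nM. It shares this position with the other two compounds: the limit of > 166000 nM in this assay, at which 3 of the 3 values shown sit.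

Compound 4 `Cc1cccc(CNc2ncnc3c2ncn3[C@@H]2O[C@H](CO)[C@@H](O)[C@H]2O)c1O` follows from compound 3 by one change, methyl in place of hydroxy on an aromatic carbon, ortho to a hydroxy group, so that 2,3-dihydroxyphenyl becomes 2-hydroxy-3-methylphenyl: methyl in place of hydroxy on an aromatic carbon.

The measured steps that bear on this change are a step that the two limits leave unreadable from compound 1 to compound 3 and a step that the two limits leave unreadable from compound 2 to compound 3, together with a step that the two limits leave unreadable from compound 1 to compound 2. None of them has a readable size, so they give no measure of how far a change on this phenyl ring can move the result. All three changes of this group leave the compounds at the limit.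

No step beyond the scatter is therefore expected in this assay, and a report as a limit is the likeliest outcome. Any readable result would be expected on the stronger side. The expected step is an at least 1.1-fold lower number from compound 3 to compound 4 (0.04 log units; that floor lies within the scatter). For compound 4 the estimated value is 150000 nM, with an expected range from 40000 nM to 166000 nM.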

Compound 4, half-maximal inhibitory concentration: > 166000 nM
Compound 4 gave a limit, no number (the forecaster's own chance of this, stated with the estimate: 70%); at least 1.1-fold (0.04 log units) between middle value and limit.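

In this assay compound 4 gives only a limit, > 166000 nM. Its steps from compound 1, compound 2 and compound 3 therefore cannot be read: the limit of > 166000 nM in this assay, at which 4 of the 4 values shown sit.

The compounds shown leave open whether any change on this phenyl ring can bring a measurable antiproliferative value.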